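This account rests on a few compounds, and the source may have more. Where it says the series, first, only, none or still open, it means among the compounds named here.

Compounds measured so far:
compound 1 `Cc1nc(N(C)C(=O)NC(=O)c2c(F)cccc2F)sc1C(=O)N/N=C/c1ccccc1C(F)(F)F` — 7.88 ug/mL
compound 2 `CN(C(=O)NC(=O)c1c(F)cccc1F)c1nc(C(F)(F)F)c(C(=O)N/N=C/c2ccc(C(F)(F)F)cc2)s1` — 34.9 ug/mL
compound 3 `CN(C(=O)NC(=O)c1c(F)cccc1F)c1nc(C(F)(F)F)c(C(=O)N/N=C/c2ccccc2C(F)(F)F)s1` — 17 ug/mL

In a functional assay on BCG823 cells (Homo sapiens) for inhibition, read by MTT assay, with a stated time of 72 h (on this read-out higher numbers stand for weaker inhibition and lower numbers for stronger inhibition), compound 1 gives the lowest number of the three. Compound 3 stands nearest, with a 2.2-fold higher number from compound 1 to compound 3 (0.33 log units; beyond the scatter); compound 2 stands furthest, as compound 2 gives 34.9 ug/mL while compound 1 gives 7.88 ug/mL. The piece now turns to compound 4 `Cc1nc(N(C)C(=O)NC(=O)c2c(F)cccc2F)sc1C(=O)N/N=C/c1cccc(C(F)(F)F)c1`, which differs from compound 1 by 3-(trifluoromethyl)phenyl in place of 2-(trifluoromethyl)phenyl on a carbon with a double bond to nitrogen. For the measured compounds named here, one measured step bears on this change: a 2.1-fold lower number from compound 2 to compound 3 (0.31 log units; beyond the scatter), which shows that where the trifluoromethyl sits on the phenyl ring shifts the number modestly. Since compound 4 places the group at neither of those two positions, a modest rise in the number is expected, a 1.6-fold higher number from compound 1 to compound 4 (0.22 log units; within the scatter). Compound 4 is therefore estimated at 13 ug/mL, within a range of 6 ug/mL to 28 ug/mL.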

Compound 4, half-maximal inhibitory concentration: 32.7 ug/mL
Estimate against measurement, compound 4: 2.5-fold (0.40 log units) below, and the stated range ends below it.
By their numbers in this assay, from the lowest: compound 1; then compounds 3, 4 and 2 (each within the scatter of the next, the first and the last beyond it).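

In this assay, 3-(trifluoromethyl)phenyl in place of 2-(trifluoromethyl)phenyl gives a 4.1-fold higher number from compound 1 to compound 4 (0.62 log units; beyond the scatter), so the position of the trifluoromethyl matters on the methyl-bearing core as well. 2-(Trifluoromethyl)phenyl now gives the lower number in both pairs, compound 3 against compound 2 and compound 1 against compound 4, though each pair compares it with a different partner. Nothing shown explains why this change moves the number. The compounds shown leave open how 3-(trifluoromethyl)phenyl and 4-(trifluoromethyl)phenyl compare on a single core. As far as these compounds go, how an amine or a carboxylic acid on this phenyl ring would read also remains open.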